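The source may hold more compounds than are shown below. What is called first, only, known or untested is meant among the compounds shown, and "the series" means these compounds.

Measured so far:
compound 1 `CC(C)[C@@H](c1ccc(-c2ccc3cccc(F)c3c2)[nH]c1=O)[C@@H]1OC(=O)NC1=O` gives 85 nM
compound 2 `CC(C)[C@H](C[C@H]1OC(=O)NC1=O)c1ccc(-c2ccc3cccc(F)c3c2)[nH]c1=O` gives 6 nM
compound 3 `CC(C)C(CC1NC(=O)NC1=O)c1ccc(-c2ccc3cccc(F)c3c2)[nH]c1=O` gives 10 nM

These numbers come from an assay on membranes from Chem-1 cells for displacement of a labelled ligand from prostaglandin E2 receptor EP3 subtype (Homo sapiens), read by scintillation counting, with a stated time of 2 h; on this read-out higher numbers stand for weaker inhibition and lower numbers for stronger inhibition. Compound 2 stands at the lowest of the three numbers; compound 3 lies within the scatter of it, while compound 1 sits far above it. Compound 4 `CC(C)[C@@H](c1ccc(-c2ccc3cccc(F)c3c2)[nH]c1=O)[C@H]1OC(=O)NC1=O` has not yet been measured. It differs from compound 2 by 2,4-dioxo-1,3-oxazolidin-5-yl in place of (2,4-dioxo-1,3-oxazolidin-5-yl)methyl on a saturated chain carbon bound to an aromatic carbon and a saturated chain carbon. Going by the values given here, the one measured step that bears on this is a 14-fold lower number from compound 1 to compound 2 (1.15 log units; beyond the scatter), which added the same chain link that compound 4 now loses. Compound 4 is not simply compound 1 again, since its stereocentre on the ring is set the other way, so the size of the reversal is uncertain. A step upward from compound 2, a 10-fold higher number from compound 2 to compound 4 (1.00 log units; beyond the scatter), is therefore expected. Compound 4 is estimated at 60 nM, within 15 nM to 250 nM.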

Compound 4, inhibition constant: 27 nM
Compound 4: the middle estimate sits 2.2-fold (0.35 log units) above what was measured; the measured number falls inside the stated range.
By their numbers in this assay, from the lowest: compounds 2 and 3 (each within the scatter of the next); then compound 4; then compound 1.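

Losing the methyl link raises the number whichever way the ring stereocentre is drawn, and in compound 4 the result is a 4.5-fold higher number from compound 2 to compound 4 (0.65 log units; beyond the scatter). The configuration also matters in its own right, with a 3.1-fold lower number from compound 1 to compound 4 (0.50 log units; beyond the scatter). This gap can be traced to that single stereocentre because of one fact: the fact that compounds 1 and 4 differ only in the configuration as drawn.

The compounds shown leave open how the other ring configuration would behave with the methyl link kept. They also leave open whether a carboxylic acid or a longer chain on that saturated chain carbon would keep the number low.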